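Working notes: cytotoxicity at the upper end of the series

The compounds below may be only part of what the source reports. "The series", "measured", "known", "first", "only" and "open" are said of these compounds alone.

compound 1, `Clc1cccc(Cn2ccc3nc(-c4ccccc4)nc-3c2)c1`: > 100000 nM
compound 2, `c1ccc(CCCCn2ccc3nc(-c4ccccc4)nc-3c2)cc1`: 95000 nM

In an ADME assay on MDBK cells (Bos taurus) for cytotoxicity (a lower number here means that less compound is tolerated, a higher number that more compound is tolerated), compound 1 gives > 100000 nM, which is a limit of the assay and not a number. Compound 1 therefore stands at the limit of > 100000 nM in this assay, at which 1 of the 2 values shown sits, so only a range is known for it. Compound 2 gives 95000 nM in this assay, a value close to the top of the concentrations tested. Going by the values given here, no step between two measured compounds that differ in one place is available in this set.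

Compound 3, `CC(C)=CCn1ccc2nc(-c3ccccc3)nc-2c1`, is not yet measured. It differs from compound 1 by 2-methylprop-1-en-1-yl in place of 3-chlorophenyl on a saturated chain carbon bound to an aromatic nitrogen. With both measured compounds tolerated at such high concentrations, the expected step in this assay is none beyond the usual scatter, in either direction. For compound 3 the estimate is 100000 nM, expected to lie between 40000 nM and 250000 nM, which means an expected step of a number no higher from compound 1 to compound 3 (the limit leaves the size open).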

Compound 3, half-maximal cytotoxic concentration: > 100000 nM
Compound 3: only a limit was reported; the forecaster's own chance of this, stated with the estimate: 55%; the middle value lies on the limit itself.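

Going by these compounds alone, compound 1 and compound 3 both stand at a limit in this assay and not at a number; no step between them can be read. The compounds shown leave open whether 2-methylprop-1-en-1-yl in place of 3-chlorophenyl shifts the tolerated concentration at all, and in which direction.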